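The source may report more compounds than this note shows. Statements on the series, on what has been measured and on what is new or still open speak of the compounds shown alone.

Three compounds have been measured in an ADME assay on A-431 cells (Homo sapiens) for cytotoxicity, with a stated time of 48 h; a lower number here means a stronger inhibitor, a higher number a weaker inhibitor:

compound 1 `Cn1c(SCc2ccccc2)nnc1-c1cc([N+](=O)[O-])cc([N+](=O)[O-])c1` gives > 30000 nM
compound 2 `Cn1c(SCc2ccc(Cl)c(Cl)c2)nnc1-c1cc([N+](=O)[O-])cc([N+](=O)[O-])c1` gives > 30000 nM
compound 3 `O=[N+]([O-])c1cc(-c2nnc(SCc3ccc(Cl)c(Cl)c3)n2Cc2ccccc2)cc(C(F)(F)F)c1` gives > 30000 nM

The value of compound 1 in this assay is a limit of the assay and not a number. Compound 2 likewise gives only a limit in this assay. For compound 3 the result in this assay is again a limit, and this is all that is known of where compound 3 stands. The cores of compound 2 and compound 3 are not the same, and the difference between them is not broken down here.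

One structural change occurs twice among these compounds. From compound 2 to compound 1 it reads (phenyl in place of 3,4-dichlorophenyl on a saturated chain carbon bound to a sulfur). The step that the two limits leave unreadable from compound 2 to compound 1 has no readable size because both values sit at the limit of > 30000 nM in this assay, at which 3 of the 3 values shown sit. The same change, at the same place, is made from compound 3 to compound 4 `O=[N+]([O-])c1cc(-c2nnc(SCc3ccccc3)n2Cc2ccccc2)cc(C(F)(F)F)c1`, which has not yet been measured in this assay; it reads (phenyl in place of 3,4-dichlorophenyl on a saturated chain carbon bound to a sulfur).

Nothing measured here separates one compound from another. The expected step that the limit leaves unreadable from compound 3 to compound 4 is therefore close to nil, resting on the fact that the earlier change left the value at the same limit. Compound 4 is expected to give about 45000 nM in this assay, within an estimated range from 15000 nM to 150000 nM, most likely reported as a limit rather than a number.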

Compound 4, half-maximal inhibitory concentration: 10100 nM
For compound 4 the middle estimate is 4.5-fold (0.65 log units) above the measured one; measured number outside the range, below it.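

In this assay, replacing 3,4-dichlorophenyl with phenyl on a saturated chain carbon bound to a sulfur gives an at least 2.9-fold lower number from compound 3 to compound 4 (0.47 log units; beyond the scatter), a step beyond the scatter that leaves compound 4 as the only compound shown with a number. Going by these compounds, compound 3 gives > 30000 nM, which is a limit of the assay and not a number, so the true size of this step remains unknown. The same change on the core of compound 2 cannot be read, so the result neither confirms nor refutes that the change carries from one core to the other, because both ends of that earlier step sit at the limit: the limit of > 30000 nM in this assay, at which 3 of the 4 values shown sit.

The compounds shown leave open whether a single chlorine on the phenyl would already lift the value off the limit, and whether an amine or a carboxylic acid on that phenyl, or a longer chain in place of the benzyl group, would shift the number further. Also open, on these data alone, is which of the differences between the cores of compound 2 and compound 3 matters for this change, a question that a nitrile in place of the trifluoromethyl group could begin to address.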